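The source may hold more compounds than are shown below. What is called first, only, known or untested is meant among the compounds shown, and "the series" means these compounds.

Series notes. Compound 1 `CC(=O)Nc1cccc(C2CCN(CCn3c(-c4ccccc4)nc4ccccc43)CC2)c1` and compound 2 `CC(=O)Nc1cccc(C2CCN(CCCn3c(-c4cccc(C(F)(F)F)c4)nc4ccccc43)CC2)c1` have been measured in an assay for displacement of a labelled ligand from melanin-concentrating hormone receptor 1 (Homo sapiens), read by fluorescence; on this read-out higher numbers stand for weaker inhibition and lower numbers for stronger inhibition: compound 1 gives 10000 nM, while compound 2 gives 30 nM, the lowest of the two numbers and well apart from compound 1. The two structures differ in more than one place, so the gap is recorded without being traced to a single change. Compound 3 `CC(=O)Nc1cccc(C2CCN(CCCn3c(-c4ccc(C(C)C)cc4)nc4ccccc43)CC2)c1` is not yet measured. It differs from compound 2 as follows: 4-isopropylphenyl in place of 3-(trifluoromethyl)phenyl on an aromatic carbon. Among the compounds with values here, with no single-change step yet recorded in this assay, the step of a 2.0-fold higher number from compound 2 to compound 3 (0.30 log units; within the scatter) is expected to be a small loss, within or barely beyond the scatter. Compound 3 is estimated at 60 nM in this assay, in the range 15 nM to 250 nM.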

Compound 3, half-maximal inhibitory concentration: 60 nM
Estimate against measurement, compound 3: no gap at the digits printed; the measured number falls inside the stated range.
By their numbers in this assay, from the lowest: compounds 2 and 3 (each within the scatter of the next); then compound 1.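

In this assay, within the data shown here, 4-isopropylphenyl in place of 3-(trifluoromethyl)phenyl gives a 2.0-fold higher number from compound 2 to compound 3 (0.30 log units; within the scatter), the first single-change step. This aromatic carbon between two ring nitrogen atoms therefore accepts either substituted phenyl without a difference beyond the scatter, although group and ring placement differ together in this one step. No available measurement accounts for this result. The gap between compound 1 and compound 2 remains untraced to any single place. As far as these compounds go, how a carboxylic acid or an amine on this phenyl ring would read in this assay also remains open.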